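Removing One Methoxy Group from a Chalcone-Type Compound

The source may hold more compounds than are shown below. What is called first, only, known or untested is meant among the compounds shown, and "the series" means these compounds.

Measured compounds:
Compound 1, `COc1ccc(-c2cc(C(=O)/C=C/c3ccccc3)nc3cc(-c4ccccc4)nn23)cc1OC`, gives 64100 nM.
Compound 2, `COc1ccc(/C=C/C(=O)c2cc(-c3ccc(OC)c(OC)c3)n3nc(-c4ccccc4)cc3n2)cc1`, gives 50700 nM.
Compound 3, `COc1cc(-c2cc(C(=O)/C=C/c3ccc(Cl)cc3)nc3cc(-c4ccccc4)nn23)cc(OC)c1OC`, gives 53900 nM.

These three were tested in an ADME assay on HEK293 cells (Homo sapiens) for antiproliferative activity, read by MTT assay, with a stated time of 24 h; on this read-out higher numbers stand for weaker inhibition and lower numbers for stronger inhibition. Compound 2 and compound 1 differ by hydrogen in place of methoxy on an aromatic carbon, and this gave a 1.3-fold higher number from compound 2 to compound 1 (0.10 log units; within the scatter). Compound 3 and compound 2 share no single counted difference, so the difference between the two cores is not broken down here. Compound 4, `COc1ccc(-c2cc(C(=O)/C=C/c3ccc(Cl)cc3)nc3cc(-c4ccccc4)nn23)cc1OC`, is not yet measured; it differs from compound 3 by hydrogen in place of methoxy on an aromatic carbon. This is the same kind of change as that from compound 2 to compound 1, but not the same: there the hydrogen enters para to a large group, here it enters ortho to a methoxy group and meta to a large group and to a methoxy group. Because a 1.3-fold higher number from compound 2 to compound 1 (0.10 log units; within the scatter) lay within the scatter, a step of about a 1.1-fold higher number from compound 3 to compound 4 (0.03 log units; within the scatter) is expected in this assay. Compound 4 is therefore estimated at 58000 nM, expected to fall between 30000 nM and 110000 nM.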

Compound 4, half-maximal inhibitory concentration: 39100 nM
Compound 4: the middle estimate sits 1.5-fold (0.17 log units) above what was measured; the measured number falls inside the stated range.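

Removing one methoxy group gave a 1.4-fold lower number from compound 3 to compound 4 (0.14 log units; within the scatter) in this assay, while chloro in place of methoxy gave a 1.3-fold lower number from compound 2 to compound 4 (0.11 log units; within the scatter), and chloro in place of hydrogen gave a 1.6-fold lower number from compound 1 to compound 4 (0.21 log units; within the scatter). The methoxy-to-hydrogen change therefore reads the same on these two cores, but neither step can be told from no change, so this shows no real effect being carried from one core to the other: the same change on two cores in this assay, a 1.3-fold higher number (0.10 log units; within the scatter) from compound 2 to compound 1 and a 1.4-fold lower number (0.14 log units; within the scatter) from compound 3 to compound 4, 1.7-fold (0.24 log units) apart, within the scatter of two such steps Two cores are also too few to say how the change would behave on any further core.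

The compounds shown leave open whether a larger step would appear with an amine or a carboxylic acid in place of the methoxy group.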